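From Hydroxy to Acetoxy in a Cytotoxicity Test

The compounds below may be only part of what the source reports. "The series", "measured", "known", "first", "only" and "open" are said of these compounds alone.

In a functional assay on SW48 cells (Homo sapiens) for cytotoxicity, read by luminescence and CellTiter-Glo, with a stated time of 72 h (a lower number here means a stronger inhibitor, a higher number a weaker inhibitor), compound 1 `O=C1C=CC[C@@H]([C@H](O)[C@H](O[C@@H](c2ccccc2)[C@@H](O)[C@@H]2CC=CC(=O)O2)c2ccccc2)O1` gives 4100 nM and compound 2 `O=C1C=CC[C@@H]([C@H](O)[C@@H](O[C@H]([C@@H]2CC=CC(=O)O2)[C@@H](O)c2ccccc2)c2ccccc2)O1` gives 5500 nM. Among the compounds with values here, these two values lie within the usual scatter of each other, so compound 1 does not stand apart from the only other measured compound. Compound 3 `CC(=O)O[C@@H]([C@@H]1CC=CC(=O)O1)[C@H](O[C@@H](c1ccccc1)[C@@H](O)[C@@H]1CC=CC(=O)O1)c1ccccc1` has acetyl in place of hydrogen on an oxygen on a saturated carbon, a hydroxy to acetoxy change (acetyl in place of hydrogen on an oxygen on a saturated carbon). Within the data shown here, no measured pair shows the effect of this change, so in this assay no step beyond the scatter is expected, only a small one: a 1.4-fold lower number from compound 1 to compound 3 (0.14 log units; within the scatter). For compound 3, the estimated value is 3000 nM, with a range of 900 nM to 9000 nM.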

Compound 3, half-maximal inhibitory concentration: 4100 nM
Compound 3: middle estimate off by 1.4-fold (0.14 log units), on the low side; measured number inside the range.
By their numbers in this assay, from the lowest: compounds 1, 3 and 2 (each within the scatter of the next).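

In this assay, within the data shown here, the step with acetyl in place of hydrogen on an oxygen on a saturated carbon reads no change at the digits printed from compound 1 to compound 3 (within the scatter) and gives the first measured look at this hydroxy to acetoxy change. It shows that this oxygen can carry an acetyl without the number moving beyond the scatter, something compounds 1 and 2 alone could not show. No evidence at hand explains this result.

Going by these compounds, it remains open how a longer chain on this oxygen, such as butanoyl, would read. On these data alone, an amine in place of the hydroxy is equally open.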